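The compounds below may be only part of what the source reports. "The series", "measured", "known", "first", "only" and "open" are said of these compounds alone.

In a functional assay on HCT-116 cells (Homo sapiens) for cytotoxicity, read by MTT assay, with a stated time of 72 h (on this read-out higher numbers stand for weaker inhibition and lower numbers for stronger inhibition), compound 1 (`CN(C)CCCCCn1c2c(c3ccccc31)C(=O)c1c[n+]([O-])c3ccccc3c1C2=O`) gives 470 nM. That lies within the scatter of compound 3 (`O=C1c2c[n+]([O-])c3ccccc3c2C(=O)c2c1c1ccccc1n2Cc1cn(CC(O)CO)nn1`) at 250 nM, whereas compound 2 (`CC1(C)OCC(Cn2cc(Cn3c4c(c5ccccc53)C(=O)c3c[n+]([O-])c5ccccc5c3C4=O)nn2)O1`) shows a lower number, 70 nM, beyond the scatter of compound 1. Compound 4 (`CN1CCN(CCCCn2c3c(c4ccccc42)C(=O)c2c[n+]([O-])c4ccccc4c2C3=O)CC1`) has not yet been measured. It keeps the core of compound 1 and differs only at the end of the side chain: 4-methylpiperazin-1-yl in place of (dimethylamino)methyl on a saturated chain carbon, four bonds along the chain from an aromatic nitrogen. The change sits on a saturated chain carbon, four bonds along the chain from an aromatic nitrogen. Among the compounds with values here, no measured compound carries the 4-methylpiperazin-1-yl group, so the evidence is indirect. Within the data shown here, two measured steps show how far side-chain changes have moved the number so far: a 1.9-fold lower number from compound 1 to compound 3 (0.27 log units; within the scatter), which swaps the chain for a quite different one, and a 3.6-fold higher number from compound 2 to compound 3 (0.55 log units; beyond the scatter), a modest step. Neither is large, so only a small change with no clear direction is expected in this assay. The expected result is a 1.2-fold lower number from compound 1 to compound 4 (0.07 log units; within the scatter), which would stay within the scatter. The estimate for compound 4 is 400 nM, with an expected range from 150 nM to 1100 nM.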

Compound 4, half-maximal inhibitory concentration: 10 nM
Estimate against measurement, compound 4: 40-fold (1.60 log units) above; the measured number lies below the stated range.
By their numbers in this assay, from the lowest: compound 4; then compound 2; then compounds 3 and 1 (each within the scatter of the next).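

In this assay, 4-methylpiperazin-1-yl in place of (dimethylamino)methyl gives a 47-fold lower number from compound 1 to compound 4 (1.67 log units; beyond the scatter), so the end of this chain, four bonds along from an aromatic nitrogen, can move the number far more than the earlier side-chain steps did. The step with 3-(4-methylpiperazin-1-yl)propyl in place of 1-(2,3-dihydroxypropyl)-1H-1,2,3-triazol-4-yl, a 25-fold lower number from compound 3 to compound 4 (1.40 log units; beyond the scatter), is also large, so the gain holds against two quite different side chains. What lies behind these drops cannot be told from the data at hand.

The compounds shown do not separate the contribution of the ring from that of its second nitrogen or its methyl group. A piperidin-1-yl or morpholin-4-yl group at the same place, or 4-methylpiperazin-1-yl on a longer chain, would test those parts one at a time.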